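The source may report more compounds than this note shows. Statements on the series, on what has been measured and on what is new or still open speak of the compounds shown alone.

In a functional assay on HeLa cells (Homo sapiens) for antiproliferative activity, with a stated time of 24 h (a lower number here means a stronger inhibitor, a higher number a weaker inhibitor), the measured compounds read:

- compound 1 `NC(=O)c1c(NC(=O)c2ccc(C(F)(F)F)cc2)sc2c1CCN(Cc1ccc(Cl)cc1Cl)C2`: > 50000 nM (a limit)
- compound 2 `Cc1ccc(C(=O)Nc2sc3c(c2C(N)=O)CCN(Cc2ccc(Cl)cc2Cl)C3)cc1`: > 50000 nM (a limit)
- compound 3 `NC(=O)c1c(NC(=O)c2ccccc2F)sc2c1CCN(Cc1cccc(Cl)c1)C2`: 49500 nM

For the measured compounds named here, compound 3 gives 49500 nM, the only true number of the three. Compound 1 and compound 2 offer no number, as both stop at the limit of > 50000 nM in this assay, at which 2 of the 3 values shown sit.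

Compound 4 `NC(=O)c1c(NC(=O)c2ccccc2F)sc2c1CCN(Cc1ccc(Cl)cc1Cl)C2` differs from compound 3 in one place: 2,4-dichlorophenyl in place of 3-chlorophenyl on a saturated chain carbon bound to an amine nitrogen in a ring. In words, 2,4-dichlorophenyl replaces 3-chlorophenyl on a saturated chain carbon bound to an amine nitrogen in a ring, or 3-chlorobenzyl becomes 2,4-dichlorobenzyl.

Going by the values given here, the only measured step is a step that the two limits leave unreadable from compound 1 to compound 2. It swaps methyl in place of trifluoromethyl on an aromatic carbon, so it gives no size to carry over. The better clue is that compound 1 and compound 2 already carry 2,4-dichlorobenzyl and both sit at the limit of > 50000 nM in this assay, at which 2 of the 3 values shown sit. A small move towards a higher number in this assay is therefore expected, and the assay may report only a limit. The expected change is a 1.1-fold higher number from compound 3 to compound 4 (0.05 log units; within the scatter). The estimate for compound 4 is 55000 nM, with an expected range of 30000 nM to 100000 nM.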

Compound 4, half-maximal inhibitory concentration: 27500 nM
For compound 4 the middle estimate is 2.0-fold (0.30 log units) above the measured one, outside the stated range (below it).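

In this assay, the change from 3-chlorobenzyl to 2,4-dichlorobenzyl on the shared core gives a 1.8-fold lower number from compound 3 to compound 4 (0.26 log units; within the scatter), so this position tolerates the second chlorine without any readable shift. With 2,4-dichlorobenzyl held in place, the group on the carbonyl carbon now comes into view: 2-fluorophenyl gives an at least 1.8-fold lower number from compound 2 to compound 4 (0.25 log units; that floor lies within the scatter) and an at least 1.8-fold lower number from compound 1 to compound 4 (0.25 log units; that floor lies within the scatter), which shows that 2,4-dichlorobenzyl alone does not hold a compound at the limit. Compound 1 and compound 2 each give only a limit, so both of these steps are floors, and their true size stays unread: the limit of > 50000 nM in this assay, at which 2 of the 4 values shown sit.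

From the compounds shown here alone, whether a methoxy group or a pyridine ring at the benzyl position would move the number beyond the scatter remains open. So does the effect of an amine or a carboxylic acid on the phenyl ring at the carbonyl carbon.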